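The source may hold more compounds than are shown below. What is called first, only, known or untested is meant among the compounds shown, and "the series" means these compounds.

Compounds measured so far:
compound 1 `CCOC(=O)c1cnn(CC(O)CC)c1NC(=O)NC(C)C` — > 10 nM
compound 2 `CCOC(=O)c1cnn(CC(C)O)c1NC(=O)Nc1cccc(F)c1` — > 10 nM

Both compounds share the same core and differ in the group on the amide-type nitrogen and in the chain carrying the hydroxyl. In a functional assay on cells (Neutrophil, Homo sapiens) for inhibition, with a stated time of 10 min (on this read-out lower numbers stand for stronger inhibition and higher numbers for weaker inhibition), compound 1 gives > 10 nM, which is a limit of the assay rather than a number. In this assay compound 2 gives > 10 nM, likewise a limit and not a number. Among the measured compounds shown here, compound 2 therefore stands exactly where every measured value stands, at the limit of > 10 nM in this assay, at which 2 of the 2 values shown sit; no measured compound reaches a number in this assay.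

The unmeasured compound 3 `CCOC(=O)c1cnn(CC(C)O)c1NC(=O)NC(C)C` differs from compound 2 by isopropyl in place of 3-fluorophenyl on an amide-type nitrogen. Compound 1 already carries isopropyl at that place and reports only a limit, so nothing measured shows this exchange moving the read-out beyond the usual scatter. The expected step that the limit leaves unreadable from compound 2 to compound 3 is accordingly no change beyond the scatter. Compound 3 is estimated at 30 nM, with a range from 10 nM to 300 nM, and the assay is expected most likely to report again only its limit.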

Compound 3, half-maximal inhibitory concentration: 90 nM
The estimate for compound 3 lay 3.0-fold (0.48 log units) below the measured number; the range from low to high includes it.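

Compound 3 gives a number in this assay, but compound 1 and compound 2 report only a limit, so neither step to compound 3 can be read in size: the limit of > 10 nM in this assay, at which 2 of the 3 values shown sit. What the compounds shown leave open is how far compound 1 and compound 2 actually lie from compound 3, and therefore what either exchange does to inhibition.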